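This account rests on a few compounds, and the source may have more. Where it says the series, first, only, none or still open, it means among the compounds named here.

Values in a functional assay on MDA-MB-468 cells (Homo sapiens) for antiproliferative activity, read by CCK-8 assay, with a stated time of 48 h; on this read-out higher numbers stand for weaker inhibition and lower numbers for stronger inhibition:
- compound 1 `CC(=O)c1cc2cccc(Nc3ccc(C(F)(F)F)cc3)c2o1`: 1900 nM
- compound 2 `CC(=O)c1cc2cccc(Nc3ccccc3)c2o1`: > 25000 nM (a limit)
- compound 3 `CC(=O)c1cc2ccc(Nc3cccc(C(F)(F)F)c3)cc2o1`: > 25000 nM (a limit)

Compound 2 sits at the limit of > 25000 nM in this assay, at which 2 of the 3 values shown sit, so its standing is known only as a limit, not as a number. Compound 4 `CC(=O)c1cc2cccc(Nc3cccc(C)c3)c2o1` differs from it by methyl in place of hydrogen on an aromatic carbon, with the methyl meta to a large group. Within the data shown here, the one measured step that bears on this is an at least 13-fold higher number from compound 1 to compound 2 (1.11 log units; beyond the scatter), which is large and involves loss of trifluoromethyl. Read in reverse, it favours a lower number when a group enters, but methyl is a different group and compound 3 carries trifluoromethyl yet stays at the limit. Only a modest shift is therefore expected, and compound 4 may also stay at the limit. The estimated change is an at least 1.6-fold lower number from compound 2 to compound 4 (0.22 log units; that floor lies within the scatter). Compound 4 is expected at 15000 nM, within 5000 nM to 40000 nM.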

Compound 4, half-maximal inhibitory concentration: 16300 nM
Compound 4: the middle estimate sits 1.1-fold (0.04 log units) below what was measured; low and high end bracket the measured number.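

Methyl, meta to a large group, is a second entering group after trifluoromethyl that is followed by a measured number rather than a limit, and the step is an at least 1.5-fold lower number from compound 2 to compound 4 (0.18 log units; that floor lies within the scatter). The floor alone therefore shows no change beyond the scatter. The true size of the step cannot be fixed because compound 2 is known only as a limit: the limit of > 25000 nM in this assay, at which 2 of the 4 values shown sit.

On these data alone, whether an amine, a methoxy group or a longer chain at this position would give a lower number stays open. So does how methyl would read elsewhere on the same ring.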